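Piperazine aryl swap on a shared triazine-type amide series

A few compounds are considered here, and "the series" means these few. Any claim that something is new, unique, unknown or untested is made for them only; others in the source may bear on it.

Measured so far:
compound 1 `Cc1ccc(-c2nnc(N3CCN(C(=O)CN4CCN(c5ccccc5Cl)CC4)CC3)nc2-c2ccc(C)cc2)cc1` — 859000 nM in a functional assay on MCF7 cells (Homo sapiens) for cytotoxicity, read by MTT assay, with a stated time of 24 h; on this read-out lower numbers stand for stronger inhibition and higher numbers for weaker inhibition
compound 2 `COc1ccc(-c2nnc(N3CCN(C(=O)CN4CCN(c5ccccc5OC)CC4)CC3)nc2-c2ccc(OC)cc2)cc1` — > 821000 nM in this assay

Compound 1 gives a measurable value in this assay, and it sits at the weak end of what this read-out reports. For compound 2 the read-out gives only a limit, > 821000 nM, not a number; compound 2 therefore stands at or beyond the edge of what this assay resolves, and this is the single limit among the two values (the limit of > 821000 nM in this assay, at which 1 of the 2 values shown sits). For the measured compounds named here, no step between the two measured compounds can be counted, since they differ in more than one place.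

Compound 3 `COc1ccc(-c2nnc(N3CCN(C(=O)CN4CCN(c5ccc(Cl)cc5)CC4)CC3)nc2-c2ccc(OC)cc2)cc1` is not yet measured. It differs from compound 2 in one place: 4-chlorophenyl in place of 2-methoxyphenyl on an amine nitrogen in a ring. With compound 1 at a weak measured value and compound 2 at a limit, no step beyond the scatter is expected from compound 2 to compound 3 in this assay; the estimated step is a step that the limit leaves unreadable from compound 2 to compound 3. Compound 3 is thus expected to give about 850000 nM in this assay, within 400000 nM to 2000000 nM, with a fair chance that only a limit is reported again.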

Compound 3, half-maximal inhibitory concentration: 607000 nM
Beside the measured number, compound 3's estimate is 1.4-fold (0.15 log units) above it; low and high end bracket the measured number.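

In this assay, 4-chlorophenyl in place of 2-methoxyphenyl on an amine nitrogen in a ring gives an at least 1.3-fold lower number from compound 2 to compound 3 (0.13 log units; that floor lies within the scatter). Compound 3 returns a number, 607000 nM, so with the shared core held constant, this position can carry 4-chlorophenyl and still give a reading at the weak end of this read-out. The step is a floor and not a size, and its true extent stays unknown because compound 2 is reported only as a limit: the limit of > 821000 nM in this assay, at which 1 of the 3 values shown sits.

Going by these compounds, whether a much smaller group on this nitrogen, such as methyl, or a phenyl bearing a carboxylic acid would move the number beyond the scatter remains open. For the compounds shown here, also open is how much of the reading follows the groups on the shared core, since compound 1 differs from compound 3 in more than one place and gives no step to set beside this one.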